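A few compounds are considered here, and "the series" means these few. Any claim that something is new, unique, unknown or untested is made for them only; others in the source may bear on it.

Measured so far:
compound 1, `Cc1cc(C)cc(NC(=O)CN2CCC(c3cccc[n+]3[O-])CC2)c1` — 52 nM
compound 2, `O=C(CN1CCC(c2cccc[n+]2[O-])CC1)Nc1cccc(Cl)c1Cl` — 180 nM
compound 3, `O=C(CN1CCC(c2cccc[n+]2[O-])CC1)Nc1cccc(-c2ccccc2)c1` — 360 nM

Compound 3 gives the highest number of the three in a functional assay on HEK293 cells for agonist activity at D(4) dopamine receptor (Homo sapiens), read by FLIPR; on this read-out higher numbers stand for an effect only at larger amounts of compound and lower numbers for an effect already at smaller amounts; its value and that of compound 2 lie within the scatter of each other, while compound 1 sits well below it. Compound 4, `O=C(CN1CCC(c2cccc[n+]2[O-])CC1)Nc1cccc(Cl)c1`, differs from compound 3 by chloro in place of phenyl on an aromatic carbon. Going by the values given here, the only measured step, a 3.5-fold higher number from compound 1 to compound 2 (0.54 log units; beyond the scatter), changes the same aromatic ring but not in the same way, so it bears only loosely on this change. What the data do show is that the smaller aryl groups of compound 1 and compound 2 go with lower numbers than the phenyl-bearing compound 3, although the gap between compound 2 and compound 3 is within the scatter. A modest step toward a lower number is therefore expected for compound 4, a 2.8-fold lower number from compound 3 to compound 4 (0.44 log units; beyond the scatter). Compound 4 is estimated at 130 nM, with a range from 45 nM to 400 nM.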

Compound 4, half-maximal effective concentration: 62 nM
Compound 4: the middle estimate sits 2.1-fold (0.32 log units) above what was measured; measured number inside the range.
By their numbers in this assay, from the lowest: compounds 1 and 4 (each within the scatter of the next); then compounds 2 and 3 (each within the scatter of the next).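

In this assay chloro in place of phenyl on this aromatic carbon gives a 5.8-fold lower number from compound 3 to compound 4 (0.76 log units; beyond the scatter) and so shows, in a single change, that the phenyl group goes with a higher number than chloro does here. Hydrogen in place of chloro on an aromatic carbon gives a 2.9-fold lower number from compound 2 to compound 4 (0.46 log units; beyond the scatter) and shows that the additional chloro is not needed for a low number, while 3-chlorophenyl in place of 3,5-dimethylphenyl gives a 1.2-fold higher number from compound 1 to compound 4 (0.08 log units; within the scatter) and remains within the scatter. Nothing at hand explains these steps.

Going by these compounds, whether fluoro, methoxy or a nitrile on this aromatic carbon would fall nearer to chloro or to phenyl stays open. So does whether a methyl group alone would match chloro at this place.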